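The source may report more compounds than this note shows. Statements on the series, on what has been measured and on what is new or still open speak of the compounds shown alone.

Measured in a functional assay on HeLa cells (Homo sapiens) for inhibition, read by MTT assay, with a stated time of 72 h; a lower number here means a stronger inhibitor, a higher number a weaker inhibitor:
- Compound 1 `CO[C@@H](c1ccccc1)[C@H]1O[C@@H]2CC(=O)O[C@@H]2[C@H]1O`: 8460 nM
- Compound 2 `CO[C@@H]1[C@H]2OC(=O)C[C@H]2O[C@@H]1[C@H](O)c1ccccc1`: 8630 nM
- Compound 3 `CO[C@H](c1ccccc1)[C@H]1O[C@@H]2CC(=O)O[C@@H]2[C@H]1O`: 5640 nM

In this assay, compound 3 stands within the scatter of both other compounds, so the three values form a single group with no order among them. The account now turns to compound 4 `CO[C@@H]1[C@H]2OC(=O)C[C@H]2O[C@@H]1[C@H](OC)c1ccccc1`, which has not yet been measured. It differs from compound 3 by methyl in place of hydrogen on an oxygen on a saturated carbon, a hydroxy to methoxy change: methyl in place of hydrogen on an oxygen on a saturated carbon.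

Only one measured step connects two of these compounds directly: a 1.5-fold lower number from compound 1 to compound 3 (0.18 log units; within the scatter). For the measured compounds named here, it reflects (the fact that compounds 1 and 3 differ only in the configuration as drawn), so it shows how little the value moved with that configuration but contains no example of the new methyl. Going by the values given here, no measured step makes this exact change, which leaves the direction open. The close grouping of the three values gives no reason to expect a large move in this assay, and so no shift beyond the scatter is expected. The expected step is a 1.1-fold higher number from compound 3 to compound 4 (0.03 log units; within the scatter). For compound 4 the estimated value is 6000 nM, with an expected range from 2200 nM to 16000 nM.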

Compound 4, half-maximal inhibitory concentration: 56400 nM
Estimate against measurement, compound 4: 9.4-fold (0.97 log units) below; measured number above the stated range.
By their numbers in this assay, from the lowest: compounds 3, 1 and 2 (each within the scatter of the next); then compound 4.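

In this assay, methyl in place of hydrogen on an oxygen on a saturated carbon produced the first moves beyond the scatter in this set, and it did so from both sides: a 10-fold higher number from compound 3 to compound 4 (1.00 log units; beyond the scatter), and a 6.5-fold higher number from compound 2 to compound 4 (0.82 log units; beyond the scatter). Compounds 1, 2 and 3 each keep one hydroxy and stay within a single group, while compound 4 keeps none, so only compound 4 shows that among these compounds, the value rises once the last hydroxy has become methoxy. Nothing at hand gives a cause for this rise.

The compounds shown leave open whether the rise follows the loss of the last hydroxy hydrogen or the arrival of a second methyl, a question that a compound with hydroxy on both oxygens would bear on only in part. They also leave open how a longer chain such as ethyl, or an acetyl group, on either of these oxygens would read in this assay.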